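From compound 1 to compound 4: a pyridin-3-yl exchange

A few compounds are considered here, and "the series" means these few. Any claim that something is new, unique, unknown or untested is made for them only; others in the source may bear on it.

Compound 1 `Cc1ccc2[nH]c(COc3cccc(OCC4CCOCC4)c3)c(C)c(=O)c2c1`: < 1000 nM (a limit)
Compound 2 `O=c1c(Cl)c(COc2cccc(OCC3CCOCC3)c2)[nH]c2ccccc12`: 2000 nM
Compound 3 `CC(C)c1c(COc2cccc(OCC3CCOCC3)c2)[nH]c2ccccc2c1=O`: 3000 nM

In a physicochemical assay for solubility, at pH 6.8 (on this read-out higher numbers stand for higher solubility and lower numbers for lower solubility), compound 1 gives < 1000 nM, which is a limit and not a number. Its standing in the series is known only as the limit of < 1000 nM in this assay, at which 1 of the 3 values shown sits. Compound 2 and compound 3 both return numbers.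

The unmeasured compound 4 `Cc1c(COc2cccc(OCC3CCOCC3)c2)[nH]c2ccc(-c3cccnc3)cc2c1=O` keeps the core of compound 1 and carries pyridin-3-yl in place of methyl on an aromatic carbon. The series offers a single measured step to set against this change, a 1.5-fold higher number from compound 2 to compound 3 (0.18 log units; within the scatter). That step is an exchange of isopropyl in place of chloro, so it bears on the new change only loosely and gives no direction for it. Among the measured compounds shown here, no measured step removes a methyl or brings in pyridin-3-yl. On this evidence, no step beyond the scatter is expected in this assay, and the reference point remains a limit rather than a number. The expected step is a step that the limit leaves unreadable from compound 1 to compound 4, an estimate that starts from that limit. Compound 4 is estimated at 700 nM, with an expected range from 200 nM to 2000 nM.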

Compound 4, solubility: < 1000 nM
Compound 4 gave a limit, no number; the forecaster's own chance of this, stated with the estimate: 50%; the middle value is on the limit's open side.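

Compound 1 and compound 4 both return limits and not numbers in this assay, so no step between them can be read: the limit of < 1000 nM in this assay, at which 2 of the 4 values shown sit.

The compounds shown leave open whether pyridin-3-yl in place of methyl on an aromatic carbon changes the read-out at all, and where either compound stands relative to compound 2 and compound 3.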